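From a tert-butyl amide to a sec-butyl ester

The source may hold more compounds than are shown below. What is called first, only, known or untested is meant among the compounds shown, and "the series" means these compounds.

Measured compounds:
compound 1, `C=CCNC(=O)/C=C/c1ccccc1`: 63%
compound 2, `CCCOC(=O)/C=C/c1ccccc1`: 31%
compound 3, `CC(C)(C)NC(=O)/C=C/c1ccccc1`: 34%

All three were tested in a functional assay on the whole organism for inhibition, with Brassica rapa subsp. chinensis as the target, with a stated time of 3 days, tested at 100 ppm; on this read-out higher numbers stand for more inhibition of growth at the one concentration tested and lower numbers for less inhibition of growth. Compound 3 stands second highest of the three numbers; its value and that of compound 2 lie within the scatter of each other, while compound 1 sits clearly above, as the step of a number 29 percentage points lower from compound 1 to compound 3 (beyond the scatter) shows. Compound 4, `CCC(C)OC(=O)/C=C/c1ccccc1`, has not yet been measured. It differs from compound 3 in one place: sec-butoxy in place of (tert-butyl)amino on a carbonyl carbon.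

The measured step that bears on this change is a number 3 percentage points higher from compound 2 to compound 3 (within the scatter), the exchange of propoxy for (tert-butyl)amino on the carbonyl carbon, which stayed within the scatter. Compound 4 runs that exchange the other way, from an amide back to an ester, with sec-butoxy rather than propoxy. Since the ester compound 2 and the amide compound 3 gave values within the scatter of one another, no step beyond the scatter is expected in this assay. The expected step is a number 2 percentage points lower from compound 3 to compound 4 (within the scatter). Compound 4 is therefore estimated at 32%, with a range from 15% to 50%.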

Compound 4, percent growth inhibition at one concentration: 18%
Estimate against measurement, compound 4: 14 percentage points above; measured number inside the range.
By their numbers in this assay, from the lowest: compound 4; then compounds 2 and 3 (each within the scatter of the next); then compound 1.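

Earlier, the exchange between an amide and an ester on this carbonyl carbon had stayed within the scatter, but in this assay the change from (tert-butyl)amino to sec-butoxy gives a number 16 percentage points lower from compound 3 to compound 4 (beyond the scatter), so that exchange does not leave the number unchanged in every pair. The ester group itself also matters here: one added methyl on the saturated chain carbon bound to the oxygen gives a number 13 percentage points lower from compound 2 to compound 4 (beyond the scatter), and sec-butoxy in place of allylamino gives a number 45 percentage points lower from compound 1 to compound 4 (beyond the scatter), which places compound 4 lowest of the four. Nothing available explains these differences.

From the compounds shown here alone, what a sec-butylamino or an allyloxy group would give on the same carbonyl carbon remains open. So does the effect of a longer chain on the ester oxygen, or of a carboxylic acid at this place.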